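Working notes on a small series: compound 1 to compound 4

The source may hold more compounds than are shown below. What is called first, only, known or untested is meant among the compounds shown, and "the series" means these compounds.

Three compounds have been run in an ADME assay on Vero cells (Chlorocebus sabaeus) for cytotoxicity; a higher number here means that more compound is tolerated, a lower number that less compound is tolerated. Compound 1 `N=C(NO)N/N=C/c1ccc(Cl)cc1` gives in this assay only a limit, > 100000 nM. Compound 2 `Cc1ccccc1/C=N/NC(=N)NO` likewise returns in this assay a limit, > 100000 nM. Compound 3 `N/C(=N\O)N/N=C/c1ccccc1O` also sits in this assay at a limit, > 100000 nM. Compound 1 therefore stands at the same limit as the other two, and no order among the three can be read, since every value shown is a limit (the limit of > 100000 nM in this assay, at which 3 of the 3 values shown sit).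

The open compound is compound 4 `COc1ccc(/C=N/NC(=N)NO)cc1`. From compound 1 it differs by methoxy in place of chloro on an aromatic carbon, on an aromatic carbon of a six-membered aromatic ring of carbon only. Among the measured compounds shown here, no measured pair carries a change of this kind, so the expectation rests only on the fact that all three values sit at the limit (the limit of > 100000 nM in this assay, at which 3 of the 3 values shown sit). Compound 4 is expected to remain at the limit as well, with an estimate of 150000 nM and a range from 60000 nM to 500000 nM. The step that the limit leaves unreadable from compound 1 to compound 4 is expected to be none beyond the scatter.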

Compound 4, half-maximal cytotoxic concentration: > 100000 nM
Compound 4: no number, only a limit (the forecaster's own chance of this, stated with the estimate: 85%); the middle value is on the limit's open side.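

Compound 4, like compound 1, gives only a limit, so no step between them can be read in this assay: the limit of > 100000 nM in this assay, at which 4 of the 4 values shown sit.

The compounds shown leave open how far each lies beyond that limit, and so whether methoxy and chloro differ at all in this assay.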